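This account rests on a few compounds, and the source may have more. Where it says the series, first, only, none or still open, it means among the compounds named here.

Measured so far:
- compound 1 `Cc1nc([N+](=O)[O-])cn1CC(=O)NCc1ccccc1`: 77600 nM
- compound 2 `Cc1nc([N+](=O)[O-])cn1S(=O)(=O)c1ccc([N+](=O)[O-])cc1`: 611000 nM

In an ADME assay on MDCK cells (Canis lupus familiaris) for cytotoxicity, read by MTT assay, with a stated time of 72 h (on this read-out higher numbers stand for lower toxicity in this test and lower numbers for higher toxicity in this test), compound 2 gives 611000 nM, the higher of the two numbers. Compound 1 gives 77600 nM, and this gap lies beyond the usual scatter of repeated measurements. The two compounds differ in more than one place, so their gap cannot be pinned on any single group.

Compound 3 `COc1ccc(S(=O)(=O)n2cc([N+](=O)[O-])nc2C)cc1` is compound 2 with one change: methoxy in place of nitro on an aromatic carbon, para to a large group (methoxy in place of nitro on an aromatic carbon). Within the data shown here, no measured pair shows what this exchange does in this assay, so any forecast here is rough. A modest step toward a lower number, meaning somewhat higher toxicity in this test, seems the likeliest outcome. Among the measured compounds shown here, the reasoning is simple: compound 2 at 611000 nM is the top of only two values, and a new compound seems more likely to fall back from that top than to rise far past it. The estimated step is a 2.4-fold lower number from compound 2 to compound 3 (0.39 log units; beyond the scatter). For compound 3 the expected value is 250000 nM, with an estimated range of 70000 nM to 800000 nM.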

Compound 3, half-maximal cytotoxic concentration: 321000 nM
Compound 3: the middle estimate sits 1.3-fold (0.11 log units) below what was measured; the measured number falls inside the stated range.
By their numbers in this assay, from the lowest: compound 1; then compounds 3 and 2 (each within the scatter of the next).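

In this assay, putting methoxy in place of nitro on an aromatic carbon, para to a large group, gives a 1.9-fold lower number from compound 2 to compound 3 (0.28 log units; within the scatter) and so leaves the two compounds indistinguishable on this read-out. Among these compounds, this is the only measured pair for this exchange, and it shows that, in this one setting, a nitro group can be replaced by methoxy, a group with fewer heavy atoms and fewer hydrogen-bond acceptors, without a difference that stands clear of the normal variation between repeated measurements. Nothing measured on these compounds points to a reason for this outcome.

Still open, as far as these compounds go, is whether other groups on this same aromatic carbon, such as an amine, a carboxylic acid or a chlorine atom, would also stay within the normal variation of compound 2 or would instead move the number clearly in one direction. A single pair also cannot show whether methoxy in place of nitro would give a similar result on another carbon of this ring or on a compound with a different group attached to the shared core.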